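The source may report more compounds than this note shows. Statements on the series, on what has been measured and on what is new or still open speak of the compounds shown alone.

Compound 3 `Cc1ccc2nc(NC(=O)CCCc3ccccc3)sc(=O)c2c1` gives the lowest number shown in an assay on CHO cells for displacement of a labelled ligand from adenosine receptor A3 (Homo sapiens), read by scintillation counting, with a stated time of 60 min (on this read-out higher numbers stand for weaker inhibition and lower numbers for stronger inhibition), at 147 nM. Compound 1 `COc1cccc(CCCC(=O)Nc2nc3ccccc3c(=O)s2)c1` gives 382 nM in this assay. Compound 2 `O=C(CCCc1ccccc1)Nc1nc2ccccc2c(=O)s1` is reported in this assay only as a limit, > 1000 nM. The change to compound 4 `O=C(CCCc1ccccc1)Nc1nc2ccc(Br)cc2c(=O)s1` is bromo in place of methyl on an aromatic carbon. Among the measured compounds shown here, two measured steps concern substitution on an aromatic carbon: an at least 2.6-fold higher number from compound 1 to compound 2 (0.41 log units; beyond the scatter), and on the core itself an at least 6.8-fold lower number from compound 2 to compound 3 (0.83 log units; beyond the scatter); both run against the limit (the limit of > 1000 nM in this assay, at which 1 of the 3 values shown sits), so their sizes are lower bounds. For the measured compounds named here, no measured step sets bromo against methyl. The step is expected to be a 1.0-fold higher number from compound 3 to compound 4 (0.01 log units; within the scatter), with no move beyond the scatter. Compound 4 is estimated at 150 nM, between 50 nM and 500 nM.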

Compound 4, inhibition constant: > 1000 nM
Compound 4: no number, only a limit (the forecaster's own chance of this, stated with the estimate: 10%); at least 6.6-fold (0.82 log units) between middle value and limit.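

On this aromatic carbon, the exchange of methyl for bromo is not neutral in this assay: the step is an at least 6.8-fold higher number from compound 3 to compound 4 (0.83 log units; beyond the scatter). Compound 4 is reported only as a limit, > 1000 nM, so the size of that step is a lower bound: the limit of > 1000 nM in this assay, at which 2 of the 4 values shown sit. The step from compound 2 to compound 4 cannot be read, as both values are limits, so bromo shows no readable gain over hydrogen here.

Still open, on these data alone, is how far compound 4 lies past its limit. Also open, as far as these compounds go, is whether ethyl, chloro or an amine on this carbon would track methyl or bromo.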